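A few compounds are considered here, and "the series" means these few. Any claim that something is new, unique, unknown or untested is made for them only; others in the source may bear on it.

Measured so far:
- compound 1 `CC#C[C@@H](CC(=O)O)c1ccc(OC[C@H]2COc3ccc(OC)cc3O2)cc1`: in a functional assay on HEK293 cells for agonist activity at Free fatty acid receptor 1 (Homo sapiens), read by fluorescence and calcium flux, with a stated time of 10 min (on this read-out lower numbers stand for smaller maximal responses and higher numbers for larger maximal responses), compound 1 gives 91%
- compound 2 `CC#C[C@@H](CC(=O)O)c1ccc(OC[C@H]2COc3ccc(OC(C)C)cc3O2)cc1`: in this assay compound 2 gives 90%
- compound 3 `CC#C[C@@H](CC(=O)O)c1ccc(OC[C@H]2COc3ccc(C#N)cc3O2)cc1`: in this assay compound 3 gives 60%

Compound 3 gives the lowest of the three numbers, and its distance to both others lies beyond the scatter: compound 2 is nearest, compound 1 furthest. The step of a number 1 percentage points lower from compound 1 to compound 2 (within the scatter) shows that swapping one oxygen-linked group for another changed little, while the steps of a number 31 percentage points lower from compound 1 to compound 3 (beyond the scatter) and a number 30 percentage points lower from compound 2 to compound 3 (beyond the scatter) show that bringing in cyano at this position cut the maximal response sharply.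

Compound 4 `CC#C[C@@H](CC(=O)O)c1ccc(OC[C@H]2COc3ccc(CO)cc3O2)cc1` has not yet been measured. It differs from compound 3 in one place: hydroxymethyl in place of cyano on an aromatic carbon. The two steps that end in compound 3 are the ones that bear on this change, since each of them removed a non-cyano group at this position and each lost a large part of the response. Among the measured compounds shown here, no measured step carries a hydroxymethyl group, so its effect is unknown. The expectation is that removing cyano recovers part of the response, an estimated step of a number 18 percentage points higher from compound 3 to compound 4 (beyond the scatter). For compound 4 the estimated value in this assay is 78%, with a range from 60% to 95%.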

Compound 4, largest response reached (Emax), in percent of the reference or control that the assay uses: 42%
For compound 4 the middle estimate is 36 percentage points above the measured one; the whole stated range lies above it.
By their numbers in this assay, from the lowest: compound 4; then compound 3; then compounds 2 and 1 (each within the scatter of the next).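

In this assay, a number 18 percentage points lower from compound 3 to compound 4 (beyond the scatter), so replacing cyano does not by itself restore the response, and this position can lose still more of it. The larger falls, a number 48 percentage points lower from compound 2 to compound 4 (beyond the scatter) and a number 49 percentage points lower from compound 1 to compound 4 (beyond the scatter), show that the two alkoxy groups, methoxy and isopropoxy, give far larger maximal responses than either cyano or hydroxymethyl, and that a group's small size alone does not secure a high response, since cyano and hydroxymethyl have the same count of heavy atoms. Nothing available here explains why hydroxymethyl gives the lowest response of the four.

Hydroxymethyl brings in a hydrogen-bond donor that cyano lacks, but these compounds cannot show whether that donor matters. Methoxymethyl, which caps that hydroxyl as an ether, would test this, and an amine at the same carbon would show how another donor-bearing group behaves.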